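The source may report more compounds than this note shows. Statements on the series, on what has been measured and on what is new or still open speak of the compounds shown alone.

Measured compounds:
- Compound 1, `Cc1cc(CCC#N)cc(C)c1Oc1cc(Nc2ccc(C#N)cc2)c(N)cc1C(=O)N(C)C`: 38200 nM
- Compound 2, `Cc1cc(CCC#N)cc(C)c1Oc1cc(Nc2ccc(C#N)cc2)c(N)cc1C(=O)NC1CC1`: 121000 nM

Both values come from an ADME assay on TZM cells (Homo sapiens) for cytotoxicity, with a stated time of 1 days; a lower number here means that less compound is tolerated, a higher number that more compound is tolerated. For the measured compounds named here, of the two numbers, compound 2 has the higher one, and its only neighbour is compound 1, which sits a 3.2-fold higher number from compound 1 to compound 2 (0.50 log units; beyond the scatter) apart; that step came with a change from dimethylamino to cyclopropylamino on a carbonyl carbon.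

Compound 3, `Cc1cc(CCC#N)cc(C)c1Oc1cc(Nc2ccc(C#N)cc2)c(N)cc1C(=O)NC(C)C`, has not yet been measured in this assay. It differs from compound 2 in one place: isopropyl in place of cyclopropyl on an amide-type nitrogen. Going by the values given here, the only measured step, a 3.2-fold higher number from compound 1 to compound 2 (0.50 log units; beyond the scatter), exchanges one amine substituent on the carbonyl for another, as does the step to compound 3, but the groups involved are not the same, so it gives only a rough guide. The cyclopropyl and isopropyl groups carry the same count of heavy atoms and differ only in whether a ring is present, which suggests a change no larger than the one already seen and possibly none beyond the scatter. Compound 3 is therefore expected to give about 100000 nM in this assay, within a range of 40000 nM to 250000 nM, which corresponds to an expected step of a 1.2-fold lower number from compound 2 to compound 3 (0.08 log units; within the scatter).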

Compound 3, half-maximal cytotoxic concentration: 184000 nM
For compound 3 the middle estimate is 1.8-fold (0.26 log units) below the measured one; the range from low to high includes it.
By their numbers in this assay, from the lowest: compound 1; then compounds 2 and 3 (each within the scatter of the next).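

In this assay, exchanging the three-membered ring of cyclopropyl for the open isopropyl group on the amide-type nitrogen gives a 1.5-fold higher number from compound 2 to compound 3 (0.18 log units; within the scatter), so the ring makes no difference that this assay can distinguish, even though both groups carry the same heavy-atom count. The comparison with dimethylamino now rests on two groups instead of one: a 4.8-fold higher number from compound 1 to compound 3 (0.68 log units; beyond the scatter) places compound 1 apart from compound 3 just as a 3.2-fold higher number from compound 1 to compound 2 (0.50 log units; beyond the scatter) places it apart from compound 2. Nothing available here explains why compound 1 gives the lowest number of the three.

The compounds shown keep to small carbon groups on this nitrogen, so it remains open whether a longer chain such as n-butyl, a group such as tert-butyl, or a chain ending in an amine or a carboxylic acid would stay in the same range. As far as these compounds go, it is also open whether the distance from compound 1 follows from dimethylamino in particular, since a single dialkylamino group offers no comparison with another such as diethylamino.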